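Cytotoxicity limits in the series and a pyrrole analogue

The compounds below may be only part of what the source reports. "The series", "measured", "known", "first", "only" and "open" are said of these compounds alone.

Measured compounds:
Compound 1 `c1ccc(-c2ccc(Cn3cncc3CNc3ccc(-c4nc5ccccc5s4)c(-c4ccccc4)c3)cc2)cc1` gives > 1000 nM in a toxicity assay on NIH3T3 cells (Mus musculus) for cytotoxicity, read by resazurin assay (a higher number here means that more compound is needed for the effect, a lower number that less compound is needed), a limit of the assay.
Compound 2 `COC(=O)c1ccc(NCc2cncn2Cc2ccc(-c3ccccc3)cc2)cc1-c1ccccc1` gives > 1000 nM in this assay, also a limit.
Compound 3 `O=C(OC1CCCCC1)c1ccc(NCc2cncn2Cc2ccc(-c3ccccc3)cc2)cc1-c1ccccc1` gives > 10000 nM in this assay, also a limit.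

Compound 3 thus stands only at a limit, and the two other values sit at limits as well: the limit of > 1000 nM in this assay, at which 2 of the 3 values shown sit, and (the limit of > 10000 nM in this assay, at which 1 of the 3 values shown sits). Compound 4 `c1ccc(-c2ccc(Cn3cncc3CNc3ccc(-c4ccc[nH]4)c(-c4ccccc4)c3)cc2)cc1` differs from compound 3 by 1H-pyrrol-2-yl in place of cyclohexyloxycarbonyl on an aromatic carbon. Among the compounds with values here, the steps that bear on this change are a step that the two limits leave unreadable from compound 1 to compound 2, a step that the two limits leave unreadable from compound 1 to compound 3 and a step that the two limits leave unreadable from compound 2 to compound 3, each of them unreadable, the two limits leaving its size unknown. No readable step exists, so no change beyond the scatter is expected in this assay. Compound 4 is expected at 5000 nM, between 1000 nM and 30000 nM, most likely again reported only as a limit. That estimate means an expected step of an at least 2.0-fold lower number from compound 3 to compound 4 (0.30 log units; that floor lies within the scatter).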

Compound 4, half-maximal effective concentration: > 10000 nM
Compound 4 gave a limit, no number; the forecaster's own chance of this, stated with the estimate: 85%; middle value at least 2.0-fold (0.30 log units) away from the limit.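

In this assay compound 4 gives > 10000 nM, a limit of the assay. Its steps from compound 1, compound 2 and compound 3 cannot be read, as all four values are limits. The compounds shown leave open whether exchanging this group changes the cytotoxic concentration at all.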